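The source may hold more compounds than are shown below. What is called first, only, known or untested is meant among the compounds shown, and "the series" means these compounds.

Compound 1 `CCCOCC(=O)Nc1cc2nc(C3CCCCC3)[nH]c2cc1N(CC)CC` is one of three measured compounds. In an ADME assay on Vero cells (Chlorocebus sabaeus) for cytotoxicity, read by resazurin assay, with a stated time of 3 days (a lower number here means a stronger inhibitor, a higher number a weaker inhibitor), compound 1 gives > 100 ug/mL, which is a limit of the assay rather than a number. Compound 2 `CCCOCC(=O)Nc1cc2nc(C3CCCCC3)[nH]c2cc1N(C)C` gives < 50 ug/mL, also a limit. Compound 3 `CCc1ccc(C(=O)Nc2cc3nc(C4CCCCC4)[nH]c3cc2N(C)C)cc1` gives > 100 ug/mL, again a limit.

The step of an at least 2.0-fold higher number from compound 2 to compound 1 (0.30 log units; that floor lies within the scatter) goes with the change (diethylamino in place of dimethylamino on an aromatic carbon). The step of an at least 2.0-fold higher number from compound 2 to compound 3 (0.30 log units; that floor lies within the scatter) goes with the change (4-ethylphenyl in place of propoxymethyl on a carbonyl carbon). Both steps can only be given as floors, because the limit of > 100 ug/mL in this assay, at which 2 of the 3 values shown sit, and because the limit of < 50 ug/mL in this assay, at which 1 of the 3 values shown sits, leave no finished number on either side.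

Compound 4 `CCc1ccc(C(=O)Nc2cc3nc(C4CCCCC4)[nH]c3cc2N(CC)CC)cc1` has not been measured in this assay. It differs from compound 3 by diethylamino in place of dimethylamino on an aromatic carbon. Among the compounds with values here, this is the same kind of change as the one from compound 2 to compound 1, though the surroundings are not described in the same words: in compound 2 the place is ortho to a ((propoxymethyl)carbonyl)amino group (8 heavy atoms), whereas in compound 3 it is ortho to a large group. The cores of compound 2 and compound 3 differ by 4-ethylphenyl in place of propoxymethyl on a carbonyl carbon.

The earlier example of this change raised the number, and compound 3 already sits at a limit, so compound 4 is expected to sit at that limit too, meaning a step that the limit leaves unreadable from compound 3 to compound 4. Compound 4 is therefore estimated at 150 ug/mL, within 100 ug/mL to 300 ug/mL.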

Compound 4, half-maximal inhibitory concentration: > 100 ug/mL
Compound 4: only a limit was reported; the forecaster's own chance of this, stated with the estimate: 85%; the middle value lies beyond the limit too.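

In this assay compound 4 gives > 100 ug/mL, which is a limit of the assay. No new step can be read from compound 3 or compound 1 to compound 4, since both sides of each pair sit at the same limit: the limit of > 100 ug/mL in this assay, at which 3 of the 4 values shown sit.

The compounds shown leave open how much diethylamino in place of dimethylamino, or 4-ethylphenyl in place of propoxymethyl, changes the number beyond that limit.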